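The source may report more compounds than this note shows. Statements on the series, on what has been measured and on what is new or still open speak of the compounds shown alone.

Compound 1 `CCCCCCCCSc1nc(N)nc2c1ncn2/C=C1/CC1(CO)CO` gives > 20000 nM in an ADME assay on Akata cells (Homo sapiens) for cytotoxicity, with a stated time of 7 days (a higher number here means that more compound is tolerated, a lower number that less compound is tolerated), which is a limit of the assay and not a number.
Compound 2 `CCCCCCSc1nc(N)nc2c1ncn2/C=C1/CC1(CO)CO` gives > 20000 nM in this assay, again only a limit.
Compound 3 `CCCCCCOc1nc(N)nc2c1ncn2/C=C1/CC1(CO)CO` gives > 20000 nM in this assay, again only a limit.

The change hydrogen in place of ethyl on a saturated chain carbon, six bonds along the chain from a sulfur leads from compound 1 to compound 2, and the step that the two limits leave unreadable from compound 1 to compound 2 cannot be sized, since both values sit at the limit of > 20000 nM in this assay, at which 3 of the 3 values shown sit. Compound 4 `CCCCOc1nc(N)nc2c1ncn2/C=C1/CC1(CO)CO` is not yet measured; it arises from compound 3 by hydrogen in place of ethyl on a saturated chain carbon, four bonds along the chain from an oxygen on an aromatic ring, the same kind of change, though here the saturated chain carbon lies four bonds along the chain from an oxygen on an aromatic ring rather than six bonds along the chain from a sulfur. The two cores differ as hexyloxy in place of octylsulfanyl on an aromatic carbon. Because every measured value rests at the limit of > 20000 nM in this assay, at which 3 of the 3 values shown sit, the step that the limit leaves unreadable from compound 3 to compound 4 is expected to remain unreadable in the same way. Compound 4 is therefore estimated at 30000 nM, most likely once more a limit, somewhere between 15000 nM and 80000 nM.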

Compound 4, half-maximal cytotoxic concentration: > 20000 nM
Compound 4: no number, only a limit (the forecaster's own chance of this, stated with the estimate: 85%); the middle value does not contradict the limit.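

The steps from compound 1, compound 2 and compound 3 to compound 4 cannot be read, because each value is a limit of the assay and not a number: the limit of > 20000 nM in this assay, at which 4 of the 4 values shown sit.

The compounds shown leave open how much of each is actually tolerated in this assay, and whether changing the chain alters that at all.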